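Benzylamino series on a shared core: halogen swap

A few compounds are considered here, and "the series" means these few. Any claim that something is new, unique, unknown or untested is made for them only; others in the source may bear on it.

Three compounds on a shared core have numbers in a functional assay on MOLT-4 cells (Homo sapiens) for inhibition, read by sulforhodamine B assay, with a stated time of 48 h; a lower number here means a stronger inhibitor of growth, a higher number a weaker inhibitor of growth. Compound 1 `Nc1cc(N)c2nc(-c3ccccc3)c(NCc3ccc(Cl)c(Cl)c3)nc2c1` gives 2090 nM. Compound 3 `CCOC(=O)[C@H](CCC(=O)O)NC(=O)c1ccc(CNc2nc3cc(N)cc(N)c3nc2-c2ccccc2)cc1` gives 1820 nM; compound 1 and compound 3 lie within the scatter of each other, so nothing separates them. Compound 2 `CCOC(=O)[C@H](CCC(=O)O)NC(=O)c1ccc(Oc2nc3cc(N)cc(N)c3nc2-c2ccccc2)cc1` gives 38900 nM, a number beyond the scatter above that of compound 1, and compound 1 therefore stands second highest of the three, close to compound 3 and far from compound 2. Within the data shown here, no step between two measured compounds that differ in one place is available, so the weight of a single change is not yet known from measurement.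

Compound 4 `Nc1cc(N)c2nc(-c3ccccc3)c(NCc3ccc(F)cc3)nc2c1` differs from compound 1 by one change: 4-fluorophenyl in place of 3,4-dichlorophenyl on a saturated chain carbon bound to a nitrogen on an aromatic ring. In this assay the step of a 1.7-fold higher number from compound 1 to compound 4 (0.22 log units; within the scatter) is expected to be small, at most on the edge of the scatter, and more likely upward than downward. Compound 4 is therefore estimated in this assay at 3500 nM, with a range from 1200 nM to 10000 nM.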

Compound 4, concentration for 50% growth inhibition: < 100000 nM
Compound 4 gave a limit, no number; the forecaster's own chance of this, stated with the estimate: 5%; the middle value does not contradict the limit.
By their numbers in this assay, from the lowest: compounds 3 and 1 (each within the scatter of the next); then compound 2.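

In this assay compound 4 gives < 100000 nM, a limit and not a number. The step from compound 1 to compound 4 therefore cannot be read: the limit of < 100000 nM in this assay, at which 1 of the 4 values shown sits.

The compounds shown leave open what 4-fluorophenyl in place of 3,4-dichlorophenyl does to growth inhibition, and the weight of any single change in this series.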